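Hydrazone aryl swap in the MKN-45 cytotoxicity series

The compounds below may be only part of what the source reports. "The series", "measured", "known", "first", "only" and "open" are said of these compounds alone.

Compound 1 `CN(C)CCn1cnnc1-c1cc(Oc2ccc(NC(=O)N/N=C/c3cccc(O)c3)cc2F)ccn1` gives 1370 nM in a functional assay on MKN-45 cells (Homo sapiens) for cytotoxicity, read by MTT assay, with a stated time of 72 h (on this read-out higher numbers stand for weaker inhibition and lower numbers for stronger inhibition), the second highest of the three numbers in hand. Compound 2 `CN(C)CCn1cnnc1-c1cc(Oc2ccc(NC(=O)N/N=C/c3ccc(Cl)cc3)cc2F)ccn1` gives 570 nM and compound 3 `CN(C)CCn1cnnc1-c1cc(Oc2ccc(NC(=O)N/N=C/c3cc(Br)c(O)c(Br)c3)cc2F)ccn1` gives 4320 nM. Compound 4 `CN(C)CCn1cnnc1-c1cc(Oc2ccc(NC(=O)N/N=C/c3c(O)ccc4ccccc34)cc2F)ccn1` differs from compound 1 by 2-hydroxynaphthalen-1-yl in place of 3-hydroxyphenyl on a carbon with a double bond to nitrogen. Among the measured compounds shown here, no measured step changes the aryl in this way; the nearest are a 2.4-fold lower number from compound 1 to compound 2 (0.38 log units; beyond the scatter) and a 3.2-fold higher number from compound 1 to compound 3 (0.50 log units; beyond the scatter), both modest and in opposite directions, so the hydrazone aryl moves the number without a clear trend from three compounds. A larger aryl replacing 3-hydroxyphenyl is therefore expected to shift this assay only modestly, with the direction uncertain, as a 1.3-fold higher number from compound 1 to compound 4 (0.12 log units; within the scatter). Compound 4 is estimated at 1800 nM, between 600 nM and 5500 nM.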

Compound 4, half-maximal inhibitory concentration: 2020 nM
The estimate for compound 4 lay 1.1-fold (0.05 log units) below the measured number, within the range that was stated.
By their numbers in this assay, from the lowest: compound 2; then compounds 1 and 4 (each within the scatter of the next); then compound 3.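

In this assay the second aromatic ring of 2-hydroxynaphthalen-1-yl is accommodated on this carbon with a double bond to nitrogen, with a 1.5-fold higher number from compound 1 to compound 4 (0.17 log units; within the scatter) as the step from 3-hydroxyphenyl. Steps to the other two aryl groups lie beyond the scatter in opposite directions, a 2.1-fold lower number from compound 3 to compound 4 (0.33 log units; beyond the scatter) and a 3.5-fold higher number from compound 2 to compound 4 (0.55 log units; beyond the scatter), so compound 4 falls inside the span those two set. Nothing on hand explains these differences.

Going by these compounds, an amine or a carboxylic acid on the aryl ring remains open, as does naphthalen-1-yl without the hydroxyl.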